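The compounds below may be only part of what the source reports. "The series", "measured", "known", "first", "only" and "open" are said of these compounds alone.

Compound 3 `O=C(Nc1cccc(-c2oc3cc(-c4ccc(F)cc4)ccc3c(=O)c2O)c1)c1cccc(F)c1` carries a (3-fluorophenyl)carbonyl on the amide nitrogen of the shared core, and in a functional assay on MCF7 cells (Homo sapiens) for antiproliferative activity, read by CCK-8 assay, with a stated time of 72 h (a lower number here means a stronger inhibitor, a higher number a weaker inhibitor), compound 3 gives 5770 nM. Among the three measured compounds this is the second highest number. Its nearest neighbour is compound 1 `O=C(Nc1cccc(-c2oc3cc(-c4ccc(F)cc4)ccc3c(=O)c2O)c1)c1ccc(Cl)cc1`, which in this assay gives 4730 nM, so that a 1.2-fold higher number from compound 1 to compound 3 (0.09 log units; within the scatter). The furthest is compound 2 `O=C(Nc1cccc(-c2oc3cc(-c4ccc(F)cc4)ccc3c(=O)c2O)c1)c1ccc(Br)cc1`, which gives 24000 nM in this assay; here a 4.2-fold lower number from compound 2 to compound 3 (0.62 log units; beyond the scatter). Between the two halogenated analogues, a 5.1-fold higher number from compound 1 to compound 2 (0.71 log units; beyond the scatter).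

Compound 4 `Cc1cc(C(=O)Nc2cccc(-c3oc4cc(-c5ccc(F)cc5)ccc4c(=O)c3O)c2)ccc1F` has not yet been measured. It differs from compound 3 in one place: 4-fluoro-3-methylphenyl in place of 3-fluorophenyl on a carbonyl carbon. Going by the values given here, none of the measured steps shows a methyl being added to this ring, so the bearing of the earlier steps is indirect. They show that swapping the ring pattern from 4-chlorophenyl to 3-fluorophenyl moved the number only within the scatter, while the chloro-to-bromo exchange produced a modest rise. On that basis the step is expected to be small, with no clear direction beyond the scatter, and the expected step is a 1.0-fold higher number from compound 3 to compound 4 (0.02 log units; within the scatter). Compound 4 is therefore estimated to give 6000 nM in this assay, within a range from 2500 nM to 15000 nM.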

Compound 4, half-maximal inhibitory concentration: 7710 nM
The estimate for compound 4 lay 1.3-fold (0.11 log units) below the measured number; measured number inside the range.
By their numbers in this assay, from the lowest: compounds 1, 3 and 4 (each within the scatter of the next); then compound 2.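

In this assay, the change from 3-fluorophenyl to 4-fluoro-3-methylphenyl on the carbonyl carbon brings in the first methyl on this ring and gives a 1.3-fold higher number from compound 3 to compound 4 (0.13 log units; within the scatter) in a step that stays within the scatter. The ring of compound 4 also stays within the scatter of the 4-chlorophenyl ring (a 1.6-fold higher number from compound 1 to compound 4 (0.21 log units; within the scatter)), whereas the comparison with the 4-bromophenyl ring gives a 3.1-fold lower number from compound 2 to compound 4 (0.49 log units; beyond the scatter) and lies beyond it, so compound 2 now stands apart from three compounds with different substituted rings at this position. The data at hand offer no measurement that accounts for these steps or for the separate standing of compound 2.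

This single step changes the place of the fluorine and adds the methyl together, so the compounds shown do not separate the two changes, and a ring with only a methyl, such as 3-methylphenyl, would be needed to do so. They also leave open how this position responds to an iodo group, a methoxy group, an amine or a carboxylic acid on the ring, and whether any of these would move the number beyond the scatter.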